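A few compounds are considered here, and "the series" means these few. Any claim that something is new, unique, unknown or untested is made for them only; others in the source may bear on it.

Measured compounds:
- compound 1 `Cc1ncccc1OC[C@@H]1CCCN1C`: 4800 nM in an assay on K177 cells for activation of Neuronal acetylcholine receptor; alpha4/beta2 (Homo sapiens); a higher number here means that more compound is needed for the effect, a lower number that less compound is needed
- compound 2 `CN1CCC[C@H]1COc1cccnc1Br`: > 1000000 nM in this assay, which is a limit of the assay and not a number
- compound 3 `Cc1ccncc1OC[C@@H]1CCCN1C`: 2100 nM in this assay

Compound 3 holds the lowest of the two numbers shown, with 2100 nM; the nearest is compound 1, which sits a step higher at 4800 nM, a gap beyond the scatter. The third value, that of compound 2, is only a limit (the limit of > 1000000 nM in this assay, at which 1 of the 3 values shown sits).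

The next compound is compound 4 `CN1CCC[C@H]1COc1cnccc1Br`. It differs from compound 3 by bromo in place of methyl on an aromatic carbon.

For the measured compounds named here, the one measured step of the same kind is an at least 200-fold higher number from compound 1 to compound 2 (2.31 log units; beyond the scatter), in which the bromo entered on the core of compound 1. On these data alone, that step ran up to the limit, so its true size is unknown beyond being large. Compound 4 carries the same exchange on the core of compound 3, at a different carbon of the ring, so a step of similar character is expected: a large rise in this assay, quite possibly again ending at the limit.

On that basis compound 4 is expected to show 300000 nM in this assay, within 20000 nM to 2000000 nM, an expected step of a 140-fold higher number from compound 3 to compound 4 (2.15 log units; beyond the scatter).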

Compound 4, half-maximal effective concentration: > 1000000 nM
Compound 4: only a limit was reported; the forecaster's own chance of this, stated with the estimate: 50%; at least 3.3-fold (0.52 log units) between middle value and limit.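

Compound 4 gives > 1000000 nM in this assay, which is a limit of the assay and not a number. Bromo in place of methyl on this aromatic carbon, opposite the ring nitrogen and ortho to a group of 8 heavy atoms, gives a large rise, an at least 470-fold higher number from compound 3 to compound 4 (2.67 log units; beyond the scatter), so the large rise seen earlier on the core of compound 1 is no longer confined to that one core. With two cores now showing a large rise in the same direction, the change reads as consistent across the compounds shown, though its size can be bounded only from one side: the same change on two cores in this assay, an at least 200-fold higher number (2.31 log units; beyond the scatter) from compound 1 to compound 2 and an at least 470-fold higher number (2.67 log units; beyond the scatter) from compound 3 to compound 4; the limit leaves it open whether they differ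

On these data alone, how far the true values of compound 2 and compound 4 lie past the limit stays open, and so does any ranking of the two steps. Also open, as far as these compounds go, is whether the loss is specific to bromo or extends to other replacements of methyl on this carbon, such as chloro, fluoro, an ethyl chain, a methoxy group or an amine, any of which would show how much change the position accepts.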